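Ethyl in place of acid hydrogen on the shared core

A few compounds are considered here, and "the series" means these few. Any claim that something is new, unique, unknown or untested is made for them only; others in the source may bear on it.

Measured compounds:
compound 1 `CCC(C)Oc1ccccc1-c1ncc(C(=O)O)c(=O)[nH]1`: 0.5 mg/kg
compound 2 `O=C(O)c1cnc(-c2ccccc2OCc2ccccc2)[nH]c1=O`: 5 mg/kg

In a functional assay on the whole organism (strain Sprague-Dawley) for inhibition, with Rattus norvegicus as the target, with a stated time of 10 min (on this read-out lower numbers stand for an effect already at smaller amounts and higher numbers for an effect only at larger amounts of compound), compound 1 gives 0.5 mg/kg, the lowest of the two numbers; its nearest neighbour is compound 2, which in this assay gives 5 mg/kg. Within the data shown here, the one step measured so far, a 10-fold higher number from compound 1 to compound 2 (1.00 log units; beyond the scatter), concerns the group on the oxygen of the aromatic ring and leaves the carboxy untouched.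

Compound 3 `CCOC(=O)c1cnc(-c2ccccc2OC(C)CC)[nH]c1=O` differs from compound 1 in one place: ethyl in place of hydrogen on an oxygen next to a carbonyl group. Among the measured compounds shown here, no measured step bears on this position, so the direction of the change cannot be read from compound 2, and the expectation rests on compound 1 alone. The number for compound 3 is estimated to lie close to compound 1, with the uncertainty spread to both sides, the expected step being a 2.0-fold higher number from compound 1 to compound 3 (0.30 log units; within the scatter). Compound 3 is therefore expected to give about 1 mg/kg, within 0.25 mg/kg to 5 mg/kg.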

Compound 3, dose for 50% inhibition: 0.5 mg/kg
Estimate against measurement, compound 3: 2.0-fold (0.30 log units) above; low and high end bracket the measured number.
By their numbers in this assay, from the lowest: compounds 1 and 3 (each within the scatter of the next); then compound 2.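

Ethyl in place of hydrogen on the oxygen next to a carbonyl group gives, in this assay, no change at the digits printed from compound 1 to compound 3 (within the scatter), the first reading at this position, since the earlier step concerned only the group on the oxygen on the aromatic ring. In this pair, with sec-butyl held constant, the free hydroxy of the carboxy is therefore not needed for a low dose number, and ethoxycarbonyl serves as well as carboxy. Nothing available explains this result.

Whether the same holds with benzyl on the oxygen on the aromatic ring, as in compound 2, stays open, as that pair is not among the compounds shown. Also open, on these data alone, is how this position responds to a primary amide, a tetrazole or an ester with a longer chain such as butyl.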